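Cytotoxicity on a benzazepinol ether series: phenoxy to fluorophenyl

The source may report more compounds than this note shows. Statements on the series, on what has been measured and on what is new or still open speak of the compounds shown alone.

Three compounds of the shared core have been run in an ADME assay on Vero cells (Chlorocebus sabaeus) for cytotoxicity, read by sulforhodamine B assay, with a stated time of 72 h; on this read-out higher numbers stand for weaker inhibition and lower numbers for stronger inhibition. Compound 1 `Cc1cccc(COc2ccc3c(c2)[C@@H](O)CN(C)C3)c1` gives a limit of > 50000 nM in this assay. Compound 2 `CN1Cc2ccc(OCCCN3CCNCC3)cc2[C@@H](O)C1` gives a limit of > 100000 nM in this assay. Within the data shown here, compound 3 `CN1Cc2ccc(OCc3ccc(Oc4ccccc4)cc3)cc2[C@@H](O)C1` is the only member with a numerical reading, 3400 nM in this assay, so it stands alone among the three as the one whose cytotoxicity could be quantified; the other two sit at the limit of > 100000 nM in this assay, at which 1 of the 3 values shown sits, and (the limit of > 50000 nM in this assay, at which 1 of the 3 values shown sits).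

Compound 4 `CN1Cc2ccc(OCc3ccc(-c4ccc(F)cc4)cc3)cc2[C@@H](O)C1` has not yet been measured in this assay. It differs from compound 3 in a single place: 4-fluorophenyl in place of phenoxy on an aromatic carbon. Among the measured compounds shown here, no measured pair changes this part of the molecule, so there is no step of this kind to lean on; the only reading for a biaryl-ether-type tail is that of compound 3, and the pair of limits for compounds 1 and 2 gives no measure of how this region moves the value.

Without a comparable step, the change a 1.2-fold higher number from compound 3 to compound 4 (0.07 log units; within the scatter) is expected to be small, within the usual scatter, with no direction favoured. For compound 4 the estimate in this assay is 4000 nM, with a range from 1500 nM to 15000 nM.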

Compound 4, half-maximal inhibitory concentration: 33800 nM
Compound 4: middle estimate off by 8.5-fold (0.93 log units), on the low side; measured number above the stated range.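

In this assay this place on the outer ring carries real weight: 4-fluorophenyl in place of phenoxy, para to a large group, gives a 9.9-fold higher number from compound 3 to compound 4 (1.00 log units; beyond the scatter), which lies beyond the scatter and is the only measured step shown for the series. The earlier compounds shown here offered one number and two limits, so they gave no size for any change, whereas this pair shows that the exchange moves the reading towards weaker inhibition even though both groups hold one six-membered aromatic ring of carbon only. Nothing measured here accounts for the step, and the assay limits on the other compounds do not bear on it.

The pair does not separate loss of the ether oxygen from gain of the fluorine, and a plain phenyl at this place, or a phenoxy carrying a 4-fluoro group, would divide the two contributions. From the compounds shown here alone, whether a chloro group, an amine or a carboxylic acid on the outer ring would move the reading further in either direction also remains open.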